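The source may hold more compounds than are shown below. What is called first, only, known or untested is meant among the compounds shown, and "the series" means these compounds.

Measured compounds:
compound 1 `C=CCCCCCCCC#CC#CC(O)CC(C)=O`: 3.34 ug/mL
compound 2 `C=CCCCCCCCC#CC#CCO`: 3.23 ug/mL
compound 3 `CCCCCCCC#CC#CCO`: 4.63 ug/mL

In a functional assay on SK-OV-3 cells (Homo sapiens) for cytotoxicity (a higher number here means that more compound is needed for the effect, a lower number that less compound is needed), compound 2 gives 3.23 ug/mL and compound 3 gives 4.63 ug/mL. The two cores differ by hydrogen in place of vinyl on a saturated chain carbon, seven bonds along the chain from a triple-bonded carbon, and the step is a 1.4-fold higher number from compound 2 to compound 3 (0.16 log units; within the scatter). Compound 1 arises from compound 2 by 2-oxopropyl in place of hydrogen on a saturated chain carbon bound to an oxygen on a saturated carbon and a triple-bonded carbon, and this change produced a 1.0-fold higher number from compound 2 to compound 1 (0.01 log units; within the scatter). Compound 4 `CCCCCCCC#CC#CC(O)CC(C)=O` arises from compound 3 by the same change, (2-oxopropyl in place of hydrogen on a saturated chain carbon bound to an oxygen on a saturated carbon and a triple-bonded carbon), at the same place. Among the compounds with values here, since the single earlier instance of this change gave a 1.0-fold higher number from compound 2 to compound 1 (0.01 log units; within the scatter), the step of a 1.0-fold lower number from compound 3 to compound 4 (0.01 log units; within the scatter) is expected to be similarly small, resting on one pair only. Compound 4 is therefore estimated at 4.5 ug/mL in this assay, with a range from 2.3 ug/mL to 8.5 ug/mL that is expected to cover the usual repeat scatter.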

Compound 4, concentration for half-maximal effect: 1.81 ug/mL
Compound 4: the middle estimate sits 2.5-fold (0.40 log units) above what was measured; measured number outside the range, below it.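

In this assay, 2-oxopropyl in place of hydrogen gives a 2.6-fold lower number from compound 3 to compound 4 (0.41 log units; beyond the scatter), and set beside the earlier instance of this change, the two steps cannot be told apart: the same change on two cores in this assay, a 1.0-fold higher number (0.01 log units; within the scatter) from compound 2 to compound 1 and a 2.6-fold lower number (0.41 log units; beyond the scatter) from compound 3 to compound 4, 2.6-fold (0.42 log units) apart, within the scatter of two such steps. The other change, hydrogen in place of vinyl, gives a 1.8-fold lower number from compound 1 to compound 4 (0.27 log units; within the scatter), and it likewise shows no difference between the two cores: the same change on two cores in this assay, a 1.4-fold higher number (0.16 log units; within the scatter) from compound 2 to compound 3 and a 1.8-fold lower number (0.27 log units; within the scatter) from compound 1 to compound 4, 2.6-fold (0.42 log units) apart, within the scatter of two such steps. Within the data shown here, this shows no firm dependence of either change on the core, but it does not show that either carries over reliably, since each comparison rests on two pairs and only one of the four steps lies beyond the scatter.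

The compounds shown leave open whether the 2-oxopropyl step would hold on a longer chain. They also leave open how an amine or a carboxylic acid in its place would behave.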